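The source may hold more compounds than are shown below. What is called first, only, known or untested is meant among the compounds shown, and "the series" means these compounds.

Compound 1, `O=C1/C(=C/c2ccncc2)CN(S(=O)(=O)c2ccc([N+](=O)[O-])cc2)C/C1=C\c1ccccc1F`: 11300 nM
Compound 2, `O=C1/C(=C/c2ccncc2)CN(S(=O)(=O)c2ccc(F)cc2)C/C1=C\c1ccccc1F`: 20300 nM

Both numbers come from a functional assay on HepG2 cells (Homo sapiens) for cytotoxicity, read by MTT assay, with a stated time of 24 h; a lower number here means a stronger inhibitor, a higher number a weaker inhibitor. Among the measured compounds shown here, compound 2 gives 20300 nM and compound 1 gives 11300 nM, and the one measured step, a 1.8-fold higher number from compound 1 to compound 2 (0.25 log units; within the scatter), leaves the two inside the scatter of each other.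

Compound 3, `N#Cc1ccc(S(=O)(=O)N2C/C(=C\c3ccncc3)C(=O)/C(=C/c3ccccc3F)C2)cc1`, differs from compound 2 by cyano in place of fluoro on an aromatic carbon. For the measured compounds named here, the only step bearing on this position is a 1.8-fold higher number from compound 1 to compound 2 (0.25 log units; within the scatter), small and within the scatter, so for compound 3 no step beyond the scatter is expected in this assay, estimated as a 1.4-fold lower number from compound 2 to compound 3 (0.13 log units; within the scatter). Compound 3 is therefore estimated at 15000 nM, between 7000 nM and 35000 nM.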

Compound 3, half-maximal inhibitory concentration: 4500 nM
Estimate against measurement, compound 3: 3.3-fold (0.52 log units) above, outside the stated range (below it).
By their numbers in this assay, from the lowest: compound 3; then compounds 1 and 2 (each within the scatter of the next).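

In this assay, this position can move the number beyond the scatter: 4-fluorophenyl to 4-cyanophenyl gives a 4.5-fold lower number from compound 2 to compound 3 (0.65 log units; beyond the scatter), and cyano in place of nitro gives a 2.5-fold lower number from compound 1 to compound 3 (0.40 log units; beyond the scatter). The earlier fluoro and nitro pair stayed within the scatter, so among these three compounds cyano alone stands apart. No measurement at hand explains this difference.

Open, on these data alone, is whether an amine, a carboxylic acid or a methoxy group here would side with cyano or with fluoro and nitro. Also open, as far as these compounds go, is whether the cyano step holds when other parts of the shared core change.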